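Benzyl change on the 4-aminocyclohexyl bromo compound

The source may hold more compounds than are shown below. What is called first, only, known or untested is meant among the compounds shown, and "the series" means these compounds.

In a functional assay on MDA-MB-435 cells (Homo sapiens) for cytotoxicity, read by MTT assay, with a stated time of 72 h (a lower number here means a stronger inhibitor, a higher number a weaker inhibitor), compound 1 `C[C@@H](Nc1c(C(=O)NCc2ccc(F)cc2)nc(Br)c2cccnc12)c1ccccc1` gives > 20000 nM, which is a limit of the assay. Compound 2 `N[C@H]1CC[C@H](Nc2c(C(=O)NCc3ccc(F)cc3)nc(Br)c3cccnc23)CC1` gives 6000 nM and compound 3 `N[C@H]1CC[C@H](Nc2c(C(=O)NCc3ccc(F)cc3)nc(N3CCCCC3)c3cccnc23)CC1` gives 5000 nM, two values within the scatter of each other, so compound 2 stands level with compound 3.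

Compound 4 `N[C@H]1CC[C@H](Nc2c(C(=O)NCc3ccc(Cl)cc3Cl)nc(Br)c3cccnc23)CC1` differs from compound 2 at one place, on a saturated chain carbon bound to an amide-type nitrogen: 2,4-dichlorophenyl in place of 4-fluorophenyl on a saturated chain carbon bound to an amide-type nitrogen. This reads as 4-fluorobenzyl to 2,4-dichlorobenzyl.

Two measured steps are available: an at least 3.3-fold lower number from compound 1 to compound 2 (0.52 log units; beyond the scatter), and a 1.2-fold lower number from compound 2 to compound 3 (0.08 log units; within the scatter). Both lie elsewhere on the molecule, and all three measured compounds carry the 4-fluorobenzyl group, so neither step gives a size or direction for this change. No step beyond the scatter is therefore expected in this assay. The expected step is a 1.2-fold lower number from compound 2 to compound 4 (0.08 log units; within the scatter).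

For compound 4 the estimated value is 5000 nM, with an expected range from 1800 nM to 14000 nM.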

Compound 4, half-maximal inhibitory concentration: 5800 nM
Compound 4: middle estimate off by 1.2-fold (0.06 log units), on the low side; measured number inside the range.
By their numbers in this assay, from the lowest: compounds 3, 4 and 2 (each within the scatter of the next). At a limit, above all of these: compound 1.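

Working notes on the benzyl position: in this assay, the change from 4-fluorobenzyl to 2,4-dichlorobenzyl gives a 1.0-fold lower number from compound 2 to compound 4 (0.01 log units; within the scatter). Among these compounds, this is the first reading at this position, on a saturated chain carbon bound to an amide-type nitrogen, and with the 4-aminocyclohexyl and bromo groups held constant, compound 2 and compound 4 stand level. Both are measured numbers, so the step can be read directly, and only compound 1 sits at a limit of the assay: the limit of > 20000 nM in this assay, at which 1 of the 4 values shown sits.

As far as these compounds go, whether compound 2 and compound 4 would also stand level with piperidin-1-yl in place of bromo remains open. Also open, from the compounds shown here alone, is whether a phenethyl group, or a benzyl group carrying a carboxylic acid or an amine, would separate from compound 2 at this position.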